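This account rests on a few compounds, and the source may have more. Where it says the series, first, only, none or still open, it means among the compounds named here.

Measured compounds in the series:

compound 2, `O=C(/C(=C\c1ccc([N+](=O)[O-])c(O)c1)S(=O)(=O)c1ccc(Br)cc1)c1c(F)c(F)c(F)c(F)c1F`: 1000 nM
compound 3, `O=C(/C(=C\c1ccc([N+](=O)[O-])c(O)c1)SCc1ccc(Br)cc1)c1ccc(Br)cc1`: 10000 nM
compound 1, `O=C(O)c1cc(/C=C(\C(=O)c2c(F)c(F)c(F)c(F)c2F)S(=O)(=O)c2ccc(Br)cc2)ccc1O`: > 100000 nM (a limit of the assay, not a number)

All three were run in a functional assay on DU-145 cells (Homo sapiens) for inhibition, read by trypan blue exclusion, with a stated time of 96 h; a lower number here means a stronger inhibitor of growth, a higher number a weaker inhibitor of growth. Compound 2 gives 1000 nM. Compound 3 differs from compound 2 in a way that is not broken down here, and compound 3 gives 10000 nM. For compound 1 the assay reports only a limit, > 100000 nM, so the step from compound 2 is itself an open-ended one: an at least 100-fold higher number from compound 2 to compound 1 (2.00 log units; beyond the scatter), where the change is 3-carboxy-4-hydroxyphenyl in place of 3-hydroxy-4-nitrophenyl on a double-bonded chain carbon bound to a double-bonded chain carbon. Because the value of compound 1 sits at the limit of > 100000 nM in this assay, at which 1 of the 3 values shown sits, the true size of that step is known only as a lower bound.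

Compound 4, `O=C(/C(=C\c1ccc(O)c(C(=O)O)c1)SCc1ccc(Br)cc1)c1ccc(Br)cc1`, is not yet measured. Among the measured compounds shown here, it is made from compound 3 by 3-carboxy-4-hydroxyphenyl in place of 3-hydroxy-4-nitrophenyl on a double-bonded chain carbon bound to a double-bonded chain carbon, which is the same change, at the same place, as the one taken from compound 2 to compound 1. For the measured compounds named here, on the single earlier instance of this change, the step from compound 3 to compound 4 in this assay is expected to be large and in the same direction, estimated as a 10-fold higher number from compound 3 to compound 4 (1.00 log units; beyond the scatter). Compound 3 already gives 10000 nM. A step of that kind would carry compound 4 close to the upper edge of what can be read, or past it. Compound 4 is therefore estimated at 100000 nM, within a range from 30000 nM to 300000 nM, with a real chance that only a limit is reported.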

Compound 4, concentration for 50% growth inhibition: 10000 nM
Estimate against measurement, compound 4: 10-fold (1.00 log units) above, outside the stated range (below it).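

On the core of compound 3, 3-carboxy-4-hydroxyphenyl in place of 3-hydroxy-4-nitrophenyl gives no change at the digits printed from compound 3 to compound 4 (within the scatter). Set beside the earlier instance, the same change at the same place does not carry its size from one core to the other in this assay: the same change on two cores in this assay, an at least 100-fold higher number (2.00 log units; beyond the scatter) from compound 2 to compound 1 and no change at the digits printed (within the scatter) from compound 3 to compound 4, at least 100-fold (2.00 log units) apart, beyond the scatter of two such steps

The two instances do not show which difference between the cores goes with this gap, and the earlier step has only a lower bound, its end point compound 1 being a limit of the assay: the limit of > 100000 nM in this assay, at which 1 of the 4 values shown sits.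

The cores of compound 2 and compound 3 differ in more than one place, so the series as shown leaves open whether the sulfur-containing link or the aryl ketone part decides how far the change reaches, and a core differing from compound 3 in only one of these places would be needed to separate them. Also open, as far as these compounds go, is how an amine or a methyl ester in place of the carboxylic acid of 3-carboxy-4-hydroxyphenyl would read in this assay on either core.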